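The compounds below may be only part of what the source reports. "The series", "measured", "known", "first", "only" and "open" are said of these compounds alone.

Measured in a functional assay on MCF7 cells (Homo sapiens) for antiproliferative activity, read by sulforhodamine B assay, with a stated time of 48 h; a lower number here means a stronger inhibitor, a higher number a weaker inhibitor:
- compound 1 `COc1ccc(/C=C/C(=O)c2ccccc2-c2ccc(F)cc2)cc1`: 670 nM
- compound 2 `COc1ccc(/C=C/C(=O)c2ccccc2-c2ccc(F)cc2)cc1OC`: 240 nM

Of these two, compound 1 has the higher number at 670 nM, which makes it the weaker inhibitor. The nearest measured neighbour is compound 2, with a 2.8-fold lower number from compound 1 to compound 2 (0.45 log units; beyond the scatter).

The next compound to be tested is compound 3 `COc1ccc(/C=C/C(=O)c2ccccc2-c2cccc(F)c2)cc1`. It has the same atoms as compound 1, joined differently: 3-fluorophenyl in place of 4-fluorophenyl on an aromatic carbon, ortho to a large group (3-fluorophenyl in place of 4-fluorophenyl on an aromatic carbon).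

Going by the values given here, only one measured step is available as a guide, and it is a different kind of change: methoxy in place of hydrogen. That step, a 2.8-fold lower number from compound 1 to compound 2 (0.45 log units; beyond the scatter), is modest, and it shows that one small change in this series can move the number beyond the scatter. Among the compounds with values here, no measured compound shows what moving the fluorine does, so the direction stays open.

In this assay, the expected result is a 1.0-fold lower number from compound 1 to compound 3 (0.01 log units; within the scatter), which means no expected step beyond the scatter. For compound 3 the estimated value is 650 nM, with an expected range from 270 nM to 1500 nM.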

Compound 3, half-maximal inhibitory concentration: 640 nM
Compound 3: middle estimate off by 1.0-fold (0.01 log units), on the high side; measured number inside the range.
By their numbers in this assay, from the lowest: compound 2; then compounds 3 and 1 (each within the scatter of the next).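

In this assay, putting 3-fluorophenyl in place of 4-fluorophenyl gives a 1.0-fold lower number from compound 1 to compound 3 (0.02 log units; within the scatter), so at this place, an aromatic carbon ortho to a large group, the two fluorinated rings cannot be told apart. The earlier step, a 2.8-fold lower number from compound 1 to compound 2 (0.45 log units; beyond the scatter), showed that adding a methoxy group can move the number beyond the scatter, whereas this pair shows that a change keeping the same atoms but joining them differently need not do so, at least for this one move of the fluorine. Nothing available explains why the two compounds read alike, and no other measurement bears on this result.

The compounds shown leave open whether the fluorine matters at all, since a plain phenyl ring or a ring carrying an amine or a nitrile at the same spot could read quite differently. They also leave open whether the extra methoxy group of compound 2 would shift the number in the same way when paired with 3-fluorophenyl.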